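The source may report more compounds than this note shows. Statements on the series, on what has been measured and on what is new or still open speak of the compounds shown alone.

Measured so far:
- compound 1 `Cc1ccc(C(=O)CSC(=S)SC(C)(C)C)cc1`: 31600 nM
- compound 2 `CCOC(=O)Nc1cccc(C(=O)CSC(=S)SCC)c1`: 2000 nM

In a functional assay on HeLa cells (Homo sapiens) for antiproliferative activity, read by resazurin assay (a lower number here means a stronger inhibitor, a higher number a weaker inhibitor), compound 1 gives 31600 nM as the higher of the two numbers, which makes it the weaker inhibitor of the pair, and the gap to compound 2 (2000 nM) lies beyond the usual scatter. The next compound to be tested is compound 3 `Cc1ccc(C(=O)CSC(=S)SCc2ccccc2)cc1`, which keeps the core of compound 1 and carries benzyl in place of tert-butyl on a sulfur. Among the compounds with values here, no two measured compounds differ in one place only, so the data offer no direct measure of this change. Within the data shown here, the only guide is that compound 2 (2000 nM) shows that much lower numbers occur in this small set, which tilts the expectation downward in this assay without fixing its size. The expected change, a 3.2-fold lower number from compound 1 to compound 3 (0.50 log units; beyond the scatter), is a moderate step toward a lower number, although a result within the scatter of compound 1 would not be surprising. For compound 3 the estimated value is 10000 nM, with an expected range from 3000 nM to 32000 nM.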

Compound 3, half-maximal inhibitory concentration: 25100 nM
The estimate for compound 3 lay 2.5-fold (0.40 log units) below the measured number, within the range that was stated.
By their numbers in this assay, from the lowest: compound 2; then compounds 3 and 1 (each within the scatter of the next).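

In this assay, within the data shown here, the step from tert-butyl to benzyl on a sulfur gives the only direct comparison in this small set, a 1.3-fold lower number from compound 1 to compound 3 (0.10 log units; within the scatter) and so within the scatter, which means that compound 1 and compound 3 cannot be told apart. On the core of compound 1, a group of 4 heavy atoms with no ring and a group of 7 heavy atoms with one six-membered aromatic ring of carbon only therefore read alike at this sulfur, something the earlier pair, which differs in more than one place, could not show. Nothing at hand accounts for this result.

From the compounds shown here alone, whether a chain ending in an amine or a carboxylic acid on this sulfur would also leave the number in place remains open. Compound 2 carries ethyl on its sulfur but differs from compound 1 in more than one place, so compound 2 at 2000 nM does not show which of its features goes with its number, and a one-place change from tert-butyl to ethyl would be needed to isolate that group.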